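This account rests on a few compounds, and the source may have more. Where it says the series, first, only, none or still open, it means among the compounds named here.

Of the compounds shown here, three have so far been tested in a functional assay on SW480 cells (Homo sapiens) for inhibition, read by MTT assay, with a stated time of 72 h; a higher number here means a weaker inhibitor of growth, a lower number a stronger inhibitor of growth. Compound 1 `N#C/C(=C\c1c(F)c(F)c(F)c(F)c1F)C(=O)c1c[nH]c2ccccc12` gives 18000 nM in this assay. Compound 2 `COc1ccc(CNC(=O)/C(C#N)=C/c2ccco2)cc1` gives 31000 nM in this assay, the higher of the two numbers; its nearest neighbour is compound 1, and the two values lie within the scatter of each other, so no order between them can be read. Compound 3 `N#C/C(=C\c1ccco1)C(=O)NCc1ccc(Cl)c(Cl)c1` reaches only the limit of > 50000 nM in this assay, with no number behind it. Compound 4 `COc1ccc(CNC(=O)/C(C#N)=C/c2ccc(Cl)cc2)cc1` has not yet been measured; it carries 4-chlorophenyl in place of furan-2-yl on a double-bonded chain carbon bound to a double-bonded chain carbon. Among the measured compounds shown here, no measured pair shows the effect of such a change, so compound 4 is expected to stay close to compound 2, with an estimated step of a 1.2-fold lower number from compound 2 to compound 4 (0.09 log units; within the scatter) no larger than the scatter. Compound 4 is therefore estimated at 25000 nM, between 8000 nM and 60000 nM.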

Compound 4, concentration for 50% growth inhibition: 10000 nM
For compound 4 the middle estimate is 2.5-fold (0.40 log units) above the measured one; the range from low to high includes it.
By their numbers in this assay, from the lowest: compounds 4, 1 and 2 (each within the scatter of the next, the first and the last beyond it). At a limit, above all of these: compound 3.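

Among the compounds shown here, replacing furan-2-yl with 4-chlorophenyl on a double-bonded chain carbon bound to a double-bonded chain carbon gives the first reading of a change in one place: in this assay there is a 3.1-fold lower number from compound 2 to compound 4 (0.49 log units; beyond the scatter). The group at this position therefore matters for growth inhibition, though the step is modest and rests on a single pair. Nothing given here accounts for the step. From the compounds shown here alone, whether the chlorine or the six-membered ring carries it stays open, and plain phenyl would separate the two. Going by these compounds, how an amine or a carboxylic acid on that ring would read is also open.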